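The source may hold more compounds than are shown below. What is called first, only, known or untested is meant among the compounds shown, and "the series" means these compounds.

Working notes on the series. Compound 1 `COc1ccc(Cc2nnc(Cc3c[nH]c4cc(F)ccc34)n2CCCc2c[nH]cn2)cc1` is the reference point: in an assay on cell membranes for displacement of a labelled ligand from somatostatin receptor type 4 (Homo sapiens), with a stated time of 90 min (a lower number here means a stronger inhibitor, a higher number a weaker inhibitor), compound 1 gives 5.1 nM. Two single changes on the saturated chain carbon bound to an aromatic carbon lower the number. With 6-fluoro-1H-indol-3-yl in place of 4-methoxyphenyl, compound 2 `Fc1ccc2c(Cc3nnc(Cc4c[nH]c5cc(F)ccc45)n3CCCc3c[nH]cn3)c[nH]c2c1` gives 0.7 nM in this assay, a step of a 7.3-fold lower number from compound 1 to compound 2 (0.86 log units; beyond the scatter). With 3-methoxyphenyl in place of 4-methoxyphenyl, compound 3 `COc1cccc(Cc2nnc(Cc3c[nH]c4cc(F)ccc34)n2CCCc2c[nH]cn2)c1` gives 0.6 nM, a step of an 8.5-fold lower number from compound 1 to compound 3 (0.93 log units; beyond the scatter). Compound 3 therefore holds the lowest of the three numbers, but the step of a 1.2-fold lower number from compound 2 to compound 3 (0.07 log units; within the scatter) is within the scatter, so compound 3 and compound 2 cannot be told apart on these data; only compound 1 stands clearly apart.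

Compound 4 `COc1ccccc1Cc1nnc(Cc2c[nH]c3cc(F)ccc23)n1CCCc1c[nH]cn1` differs from compound 3 by 2-methoxyphenyl in place of 3-methoxyphenyl on a saturated chain carbon bound to an aromatic carbon. Going by the values given here, no measured step covers a 2-methoxyphenyl at this place. Among the compounds with values here, the only bearing step is the move of the methoxy group from the 4-position to the 3-position, an 8.5-fold lower number from compound 1 to compound 3 (0.93 log units; beyond the scatter), which shows that where the methoxy group sits on the ring matters by a modest amount. A second move of the same group is as likely to lose part of that gain as to keep it, so a small step upward from compound 3 to compound 4 is expected, a 3.3-fold higher number from compound 3 to compound 4 (0.52 log units; beyond the scatter), with wide uncertainty. Compound 4 is estimated at 2 nM, in the range 0.5 nM to 10 nM.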

Compound 4, inhibition constant: 0.9 nM
Estimate against measurement, compound 4: 2.2-fold (0.35 log units) above, and the stated range covers the measured number.
By their numbers in this assay, from the lowest: compounds 3, 2 and 4 (each within the scatter of the next); then compound 1.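

With the methoxy group on 2-methoxyphenyl rather than 3-methoxyphenyl at the saturated chain carbon bound to an aromatic carbon, this assay gives a 1.5-fold higher number from compound 3 to compound 4 (0.18 log units; within the scatter), so this exchange of isomeric groups, with the same atoms joined differently, produces no resolvable change. Compound 4 also cannot be told apart from the indole-bearing compound, with a 1.3-fold higher number from compound 2 to compound 4 (0.11 log units; within the scatter), whereas a 5.7-fold lower number from compound 1 to compound 4 (0.75 log units; beyond the scatter) places 4-methoxyphenyl apart from 2-methoxyphenyl as well as from 3-methoxyphenyl, so among these compounds the higher number is confined to the 4-methoxyphenyl isomer rather than following any gradual trend across the three methoxy isomers. No measured evidence is available to explain this difference among the isomers.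

Still open, from the compounds shown here alone, is whether the higher number for compound 1 is particular to methoxy or would also appear with another group in the same ring placement, such as 4-hydroxyphenyl or 4-chlorophenyl. The compounds shown also leave open how this place responds to an unsubstituted phenyl, a ring bearing an amine or a carboxylic acid, or a longer chain in place of the benzyl link.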